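Extending the Amine End of Compound 2

This account rests on a few compounds, and the source may have more. Where it says the series, first, only, none or still open, it means among the compounds named here.

Compound 1: `NCCNC(=O)c1c(O)c2ccccc2n(-c2ccccc2)c1=O` — 7.2%
Compound 2: `NCCCCCCNC(=O)c1c(O)c2ccccc2n(-c2ccccc2)c1=O` — 11.6%

In a functional assay, with a stated time of 20 min, tested at 0.1 mM (a higher number here means a stronger effect of the compound at the concentration tested, a lower number a weaker effect), compound 1 gives 7.2% and compound 2 gives 11.6%. Of the two numbers, that of compound 2 is the larger, but the step of a number 4.4 percentage points higher from compound 1 to compound 2 (within the scatter) lies within the scatter, so the two compounds cannot be told apart on this evidence. Compound 3, `O=C(CCCCC1CCSS1)NCCCCCCNC(=O)c1c(O)c2ccccc2n(-c2ccccc2)c1=O`, has not yet been measured. It differs from compound 2 by a group of 11 heavy atoms (8 carbon, 1 oxygen, 2 sulfur; one five-membered non-aromatic ring with 2 hetero atoms) in place of a hydrogen atom, on an amine nitrogen. Going by the values given here, the only measured step, a number 4.4 percentage points higher from compound 1 to compound 2 (within the scatter), also added atoms to the chain and stayed within the scatter. It bears on the new step only loosely, as the group now entering is much larger. With no step beyond the scatter seen so far, the step of a number 0.4 percentage points higher from compound 2 to compound 3 (within the scatter) is expected to stay within the scatter as well. Compound 3 is therefore estimated at 12%, with a range from 2% to 25%.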

Compound 3, a percentage reported as activity, at one concentration (the size of the read-out at that concentration, not a potency): 6.2%
Beside the measured number, compound 3's estimate is 5.8 percentage points above it, within the range that was stated.
By their numbers in this assay, from the lowest: compounds 3, 1 and 2 (each within the scatter of the next).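

On the amine nitrogen of compound 2, a group of 11 heavy atoms (8 carbon, 1 oxygen, 2 sulfur; one five-membered non-aromatic ring with 2 hetero atoms) replaces a hydrogen atom, and this assay gives a number 5.4 percentage points lower from compound 2 to compound 3 (within the scatter) for this change. This position therefore accepts a far larger change than the chain extension among the earlier compounds without a step that can be told from the scatter, and the amine hydrogen is not shown to matter for this read-out. Nothing available explains the result or shows what the new group does.

Going by these compounds, whether any group on this nitrogen can move the number beyond the scatter remains open. A plain acetyl group or an open-chain octanoyl group would show whether the five-membered ring has any part in the result.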